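Series notes: 4-methylbenzyl to 2-fluorobenzyl on two cores

A few compounds are considered here, and "the series" means these few. Any claim that something is new, unique, unknown or untested is made for them only; others in the source may bear on it.

Measured so far in a functional assay on MDA-MB-231 cells (Homo sapiens) for cytotoxicity, read by MTT assay, with a stated time of 48 h; on this read-out lower numbers stand for stronger inhibition and higher numbers for weaker inhibition:
compound 1 `Cc1ccc(Cn2c(/C=C3\SC(=S)N(CC(=O)O)C3=O)nc3cc(Cl)ccc32)cc1` gives 13700 nM
compound 2 `Cc1ccc(Cn2c(/C=C3\SC(=S)N(CC(=O)O)C3=O)nc3ccc(Cl)cc32)cc1` gives 3960 nM
compound 3 `O=C(O)CN1C(=O)/C(=C/c2nc3cc(Cl)ccc3n2Cc2ccccc2F)SC1=S` gives 1670 nM

Compounds 1 and 2 have the same atoms joined differently; the difference between the two cores is not broken down here. Compound 3 carries the core of compound 1 and differs from it in one place only, (2-fluorophenyl in place of 4-methylphenyl on a saturated chain carbon bound to an aromatic nitrogen). In this assay, among the measured compounds shown here, this change gives an 8.2-fold lower number from compound 1 to compound 3 (0.91 log units; beyond the scatter), the only step of this kind measured so far. Compound 2 stands between the two, its number lower than that of compound 1 and higher than that of compound 3, both gaps beyond the scatter.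

Compound 4 `O=C(O)CN1C(=O)/C(=C/c2nc3ccc(Cl)cc3n2Cc2ccccc2F)SC1=S` has not been measured. For the measured compounds named here, it arises from compound 2 by 2-fluorophenyl in place of 4-methylphenyl on a saturated chain carbon bound to an aromatic nitrogen, the same change in the same place as the one from compound 1 to compound 3, but made on the core of compound 2. Because the earlier step is an 8.2-fold lower number from compound 1 to compound 3 (0.91 log units; beyond the scatter) and rests on a single pair on a different core, the carry-over to compound 4 is taken as somewhat smaller than the full earlier step, and compound 4 is expected to give a 6.6-fold lower number from compound 2 to compound 4 (0.82 log units; beyond the scatter) relative to compound 2. On that basis compound 4 is estimated at 600 nM in this assay. The expected range for compound 4 runs from 200 nM to 1800 nM.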

Compound 4, half-maximal inhibitory concentration: 9570 nM
Compound 4: middle estimate off by 16-fold (1.20 log units), on the low side; the measured number lies above the stated range.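

On the core of compound 2, the change from 4-methylbenzyl to 2-fluorobenzyl gives in this assay a 2.4-fold higher number from compound 2 to compound 4 (0.38 log units; beyond the scatter), so the change does not run in the same direction as it did on the core of compound 1. Set side by side, the two steps differ, and the effect of this change in this assay depends on the core it is made on: the same change on two cores in this assay, an 8.2-fold lower number (0.91 log units; beyond the scatter) from compound 1 to compound 3 and a 2.4-fold higher number (0.38 log units; beyond the scatter) from compound 2 to compound 4, 20-fold (1.30 log units) apart, beyond the scatter of two such steps. Among the compounds shown here, this shows that, within this series, a step measured on one core is not a safe guide to the same change on the other, but it rests on only two pairs, with one measurement behind each compound, and it does not show what in the cores causes the difference or whether either step would hold for other groups at this place.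

On these data alone, it remains open whether an unsubstituted phenyl or a methoxyphenyl on the saturated chain carbon bound to the aromatic nitrogen would follow the pattern of the core of compound 1, that of the core of compound 2, or neither. As far as these compounds go, it is also open whether the same split between cores would appear with an amide in place of the carboxylic acid.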